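The compounds below may be only part of what the source reports. "The series", "measured", "known", "first", "only" and "open" are said of these compounds alone.

Measured so far:
Compound 1, `CCC1C(=O)N(C)c2cnc(-n3ccc4cc(C(N)=O)ccc43)nc2N1c1ccn(C)n1`: > 10000 nM
Compound 2, `CCC1C(=O)N(C)c2cnc(-n3ccc4cc(C(=O)NCC(C)C)ccc43)nc2N1c1ccn(C)n1`: > 10000 nM
Compound 3, `CCC1C(=O)N(C)c2cnc(-n3ccc4cc(C(=O)NC(C)C)ccc43)nc2N1c1ccn(C)n1`: > 10000 nM

All three share one core and differ only in the group carried on the amide-type nitrogen. In an assay for inhibition of serine/threonine-protein kinase PLK3 (Homo sapiens), read by FRET and Z'-LYTE, with a stated time of 1 h (a higher number here means a weaker inhibitor, a lower number a stronger inhibitor), compound 1 gives > 10000 nM, and this is a limit of the assay, not a number. In this assay compound 2 gives > 10000 nM, again a limit. Compound 3 gives > 10000 nM, also a limit. Because (the limit of > 10000 nM in this assay, at which 3 of the 3 values shown sit), the steps among them cannot be sized: a step that the two limits leave unreadable from compound 1 to compound 2, a step that the two limits leave unreadable from compound 1 to compound 3 and a step that the two limits leave unreadable from compound 2 to compound 3 all stay unreadable, so compound 3 stands nowhere distinguishable from the other two.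

Compound 4, `CCCCNC(=O)c1ccc2c(ccn2-c2ncc3c(n2)N(c2ccn(C)n2)C(CC)C(=O)N3C)c1`, continues the same series. The change from compound 3 is butyl in place of isopropyl on an amide-type nitrogen. The steps from hydrogen to isobutyl, from hydrogen to isopropyl and from isobutyl to isopropyl are the ones that bear on it, and none of them could be read. Nothing in the data therefore points to a step beyond the scatter in either direction in this assay.

Compound 4 is accordingly expected to sit at the limit as well, with an estimated step that the limit leaves unreadable from compound 3 to compound 4 and an estimated value of 15000 nM, in a range from 5000 nM to 50000 nM.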

Compound 4, half-maximal inhibitory concentration: > 10000 nM
Compound 4 was reported as a limit; the forecaster's own chance of this, stated with the estimate: 80%; the middle value does not contradict the limit.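

In this assay compound 4 gives > 10000 nM and this is a limit, not a number. Among these compounds, no step from compound 1, compound 2 or compound 3 to compound 4 can be read, because all four values are limits: the limit of > 10000 nM in this assay, at which 4 of the 4 values shown sit. The compounds shown leave open how strongly any of them inhibits this kinase, and whether the group on the amide-type nitrogen makes any difference.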